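The compounds below may be only part of what the source reports. "The series", "measured", "known", "first", "only" and "open" are said of these compounds alone.

Three measured compounds share one core and differ only in the substitution pattern on the aromatic ring attached to the nitrogen: compound 1 `COc1ccc(CNc2ccc(/C=C/C(=O)Nc3ccccc3N)cc2)cc1`, compound 2 `COc1ccc(NCc2ccc(/C=C/C(=O)Nc3ccccc3N)cc2)cc1OC` and compound 3 `COc1cc(NCc2ccc(/C=C/C(=O)Nc3ccccc3N)cc2)cc(OC)c1OC`. In a functional assay on HCT-116 cells (Homo sapiens) for antiproliferative activity, read by MTT assay (on this read-out lower numbers stand for stronger inhibition and higher numbers for weaker inhibition), compound 1 gives 37000 nM, compound 2 gives 5000 nM and compound 3 gives 2000 nM. Compound 3 therefore holds the lowest of the three numbers; the nearest neighbour is reached by a 2.5-fold lower number from compound 2 to compound 3 (0.40 log units; beyond the scatter), and the gap to compound 1 is wider still, as the two values show. Compound 4 `COc1cc(N(C)Cc2ccc(/C=C/C(=O)Nc3ccccc3N)cc2)cc(OC)c1OC` differs from compound 3 by methyl in place of hydrogen on a nitrogen on an aromatic ring. Among the compounds with values here, no measured pair in this assay involves a change on that nitrogen; the only step on record, a 2.5-fold lower number from compound 2 to compound 3 (0.40 log units; beyond the scatter), concerns a methoxy on an aromatic carbon and does not bear directly on a methyl on the nitrogen. Without a relevant precedent, the expected step from compound 3 to compound 4 in this assay is small and of uncertain direction, a 1.3-fold higher number from compound 3 to compound 4 (0.10 log units; within the scatter). Compound 4 is thus estimated at 2500 nM, with a range from 800 nM to 8000 nM.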

Compound 4, half-maximal inhibitory concentration: 5000 nM
Compound 4: middle estimate off by 2.0-fold (0.30 log units), on the low side; the range from low to high includes it.
By their numbers in this assay, from the lowest: compound 3; then compounds 2 and 4 (each within the scatter of the next); then compound 1.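

In this assay, within the data shown here, methyl in place of hydrogen on the nitrogen gives a 2.5-fold higher number from compound 3 to compound 4 (0.40 log units; beyond the scatter) and so moves the number in the direction of weaker inhibition, the first sign that a change at this nitrogen, and not only a methoxy on an aromatic carbon, can shift the read-out beyond the scatter. The shift is modest for one added carbon, and compound 4 still gives 5000 nM in this assay, so replacing the hydrogen on this nitrogen does not abolish the measured activity. Nothing at hand explains the step. From the compounds shown here alone, whether an ethyl, a longer chain or an acetyl on this nitrogen would continue the same trend stays open. Going by these compounds, it is also open whether methyl on the nitrogen would give a similar step with the dimethoxy pattern of compound 2.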